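The compounds below may be only part of what the source reports. "The series", "measured", "known", "first", "only" and "open" are said of these compounds alone.

In a functional assay on MCF7 cells (Homo sapiens) (a higher number here means a weaker inhibitor of growth, a lower number a stronger inhibitor of growth), compound 1 `O=S(=O)(/C=C/c1ccc(F)cc1)Cc1ccc(Nc2ncnc3ccccc23)cc1` gives 16000 nM and compound 2 `O=S(=O)(/C=C/c1ccc(Br)cc1)Cc1ccc(Nc2ncnc3ccccc23)cc1` gives 91000 nM. Compound 3 `O=S(=O)(/C=C/c1ccc(F)cc1F)Cc1ccc(Nc2ncnc3ccccc23)cc1` gives > 100000 nM, which is a limit of the assay and not a number.

Compound 4 `O=S(=O)(/C=C/c1ccc(C(F)(F)F)cc1F)Cc1ccc(Nc2ncnc3ccccc23)cc1` differs from compound 3 by trifluoromethyl in place of fluoro on an aromatic carbon: trifluoromethyl takes the place of fluoro on an aromatic carbon, para to a large group and meta to a fluoro group.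

The nearest guide is a 5.7-fold higher number from compound 1 to compound 2 (0.75 log units; beyond the scatter), a modest weakening seen when bromo replaced fluoro on an aromatic carbon. The other useful guide is an at least 6.2-fold higher number from compound 1 to compound 3 (0.79 log units; beyond the scatter), which shows that adding a fluoro group also weakened growth inhibition. By contrast, an at least 1.0-fold higher number from compound 2 to compound 3 (0.04 log units; that floor lies within the scatter) has a floor within the scatter and adds little.

Neither guide points towards a stronger inhibitor, so compound 4 is expected to stay weak, with no step beyond the scatter in this assay. The expected change is a number no higher from compound 3 to compound 4 (the limit leaves the size open). For compound 4 the estimated value is 100000 nM, with an expected range of 40000 nM to 200000 nM.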

Compound 4, concentration for 50% growth inhibition: 100000 nM
Compound 4: the middle estimate sits on the measured number at the digits printed; measured number inside the range.
By their numbers in this assay, from the lowest: compound 1; then compounds 2 and 4 (each within the scatter of the next).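

In this assay there is a number no higher from compound 3 to compound 4 (the limit leaves the size open), and this step cannot be read, because compound 3 gives only a limit of the assay: the limit of > 100000 nM in this assay, at which 1 of the 4 values shown sits. Going by these compounds alone, compound 4 does give a number, which places the 2-fluoro-4-(trifluoromethyl)phenyl group on the scale for the first time, and the step from the 4-bromophenyl group is a 1.1-fold higher number from compound 2 to compound 4 (0.04 log units; within the scatter). Against compound 1 there is a 6.3-fold higher number from compound 1 to compound 4 (0.80 log units; beyond the scatter), so this group, like the 4-bromophenyl of compound 2, stays short of the 4-fluorophenyl of compound 1.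

The compounds shown leave open how far compound 4 lies from compound 3, and what trifluoromethyl does at this position without the second fluoro group. They also leave open how a nitrile or a methoxy group would compare there.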